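Swapping an Acid for a Benzyl Ether on a Shared Core

The compounds below may be only part of what the source reports. "The series", "measured", "known", "first", "only" and "open" are said of these compounds alone.

Compound 1 `Cc1ccccc1-n1nc(C)c2c1NC(=O)[C@H](C)S[C@@H]2c1ccc(-c2cccc(C(=O)O)c2)cc1` carries a 3-carboxyphenyl group on the outer ring of its core. In an assay on isolated protein for agonist activity at Bile acid receptor (Homo sapiens), read by AlphaScreen, with a stated time of 30 min (a lower number here means that less compound is needed, a higher number that more compound is needed for the effect), compound 1 is reported as "not active" (no number reported), so no number stands for it, and it cannot be ranked against any other compound on a scale.

A second compound gives a point of reference. Compound 2 `Cc1nn(-c2ccccc2Br)c2c1C(c1ccc(Oc3ccccc3)cc1)SC(C)C(=O)N2`, which bears a phenoxy group at the same outer position and a bromine on the other ring, shows 1800 nM in this assay.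

Compound 3 `Cc1ccccc1-n1nc(C)c2c1NC(=O)[C@H](C)S[C@@H]2c1ccc(OCc2ccccc2)cc1` differs from compound 1 in one place: benzyloxy in place of 3-carboxyphenyl on an aromatic carbon. The charged-capable acid group is gone and an ether-linked benzyl group takes its place.

Within the data shown here, no measured step describes this exact exchange, so the direction rests on what compound 2 shows: a neutral ether-linked aryl group at this position gives a measurable value, where the acid of compound 1 gives none. Compound 3 is therefore expected to be active in this assay, with an estimate of 2000 nM and a likely range from 500 nM to 8000 nM.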

Compound 3, half-maximal effective concentration: "not active" (no number reported)
Compound 3 has no reported number here, so the estimate cannot be set against anything.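

Compound 1 and compound 3 both stand without a number in this assay, so no step can be read between them. Nothing shown here offers an explanation for this result. The compounds shown leave open whether any group at this place on the shared core gives a measurable value with the rest of compound 1 unchanged.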